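A few compounds are considered here, and "the series" means these few. Any claim that something is new, unique, unknown or untested is made for them only; others in the source may bear on it.

Measured so far:
compound 1 `CCCCc1[nH]c(=O)c(-c2nc(Cc3ccccc3)no2)c(O)c1-c1c(OC)cccc1OC` — 69%
compound 2 `CCOCc1[nH]c(=O)c(-c2nnc(Cc3ccc(Cl)cc3)o2)c(O)c1-c1c(OC)cccc1OC` — 94%
compound 3 `CCCCc1[nH]c(=O)c(C(=O)OCC)c(O)c1-c1c(OC)cccc1OC` — 89%

Of the compounds shown here, three on a shared core have been tested in an ADME assay on microsomes from liver (Homo sapiens) for metabolic stability, read by mass spectrometry, using NADPH, with a stated time of 10 min; a lower number here means that less of the compound is left, a higher number that more of the compound is left. Compound 2 gives the highest of the three numbers, 94%. Compound 3 stands nearest to it with 89%, a gap that lies within the usual scatter, so the two cannot be told apart. Compound 1 stands furthest away with 69%, a gap that lies beyond the scatter.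

Compound 4 `CCCCc1[nH]c(=O)c(-c2nnc(Cc3ccc(Cl)cc3)o2)c(O)c1-c1c(OC)cccc1OC` has not yet been measured in this assay. It differs from compound 2 in one place: propyl in place of ethoxy on a saturated chain carbon bound to an aromatic carbon. The same chain, butyl, is carried by compound 1 and by compound 3, which return different numbers in this assay: compound 1 gives 69% and compound 3 gives 89%. On that basis a downward step is expected for compound 4, of moderate size and possibly reaching beyond the scatter, as estimated at a number 14 percentage points lower from compound 2 to compound 4 (beyond the scatter). Compound 4 is accordingly expected to give about 80% in this assay, with a likely range from 62% to 94%.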

Compound 4, percent of the compound remaining in the Homo sapiens assay: 66%
Compound 4: the middle estimate sits 14 percentage points above what was measured; the measured number falls inside the stated range.
By their numbers in the Homo sapiens assay, from the lowest: compounds 4 and 1 (each within the scatter of the next); then compounds 3 and 2 (each within the scatter of the next).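

Compound 1 and compound 3 also carry butyl, but only here can this change be read on its own: in the Homo sapiens assay, ethoxymethyl to butyl on a saturated chain carbon bound to an aromatic carbon gives a number 28 percentage points lower from compound 2 to compound 4 (beyond the scatter). The same pair also offers a second read-out, and in a physicochemical assay for solubility, in phosphate buffer, with a stated time of 24 h, at pH 7.4 (a higher number here means a more soluble compound, a lower number a less soluble compound), compound 2 gives 26 ug/mL. In the physicochemical assay compound 4 gives < 1 ug/mL, which is a limit of the assay and not a number.

This single pair leaves open whether the ether oxygen or some other feature of the chain accounts for the two differences, and it cannot say whether the same change would read alike with other groups elsewhere on the shared core. Going by these compounds, how a hydroxyl, an amine, a carboxylic acid or a longer ether chain such as methoxyethyl would stand at this position also remains open, in both the retained fraction and the solubility read-out.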